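Amine ring variation on the thiocarbonyl carbon of the series

A few compounds are considered here, and "the series" means these few. Any claim that something is new, unique, unknown or untested is made for them only; others in the source may bear on it.

Measured so far:
- compound 1 `O=c1c(CSC(=S)N2CCCC2)coc2ccccc12`: limit only
- compound 2 `CN1CCN(C(=S)SCc2coc3ccccc3c2=O)CC1`: one number

Compound 1 sits at a limit of the assay. In a functional assay on MCF7 cells (Homo sapiens) for antiproliferative activity, read by MTT assay, with a stated time of 72 h (a lower number here means a stronger inhibitor, a higher number a weaker inhibitor), compound 1 gives > 25000 nM, which is a limit and not a number. In this assay compound 2 gives 22900 nM. Going by the values given here, the one step between them, an at least 1.0-fold lower number from compound 1 to compound 2 (0.03 log units; that floor lies within the scatter), is a floor that lies within the scatter, so the two compounds cannot be ordered. Compound 2 therefore holds the only number shown in this assay; the other entry is the limit (the limit of > 25000 nM in this assay, at which 1 of the 2 values shown sits).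

Compound 3 `O=c1c(CSC(=S)N2CCOCC2)coc2ccccc12` differs from compound 2 by morpholin-4-yl in place of 4-methylpiperazin-1-yl on a thiocarbonyl carbon. Among the compounds with values here, the only measured step that bears on this change is the ring swap on the thiocarbonyl carbon from compound 1 to compound 2, and that step gave no movement beyond the scatter. With no shown step beyond the scatter at this position, no step beyond the scatter is expected in this assay, in either direction, and a limit is as likely as a number. Compound 3 is estimated at 26000 nM with a range of 11000 nM to 70000 nM. The step of a 1.1-fold higher number from compound 2 to compound 3 (0.06 log units; within the scatter) is the expected outcome.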

Compound 3, half-maximal inhibitory concentration: 4000 nM
Estimate against measurement, compound 3: 6.5-fold (0.81 log units) above; the whole stated range lies above it.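

In this assay, the amine ring on the thiocarbonyl carbon can move the number beyond the scatter, which the earlier pair did not show: morpholin-4-yl in place of 4-methylpiperazin-1-yl gives a 5.7-fold lower number from compound 2 to compound 3 (0.76 log units; beyond the scatter). Compound 2 and compound 3 both carry one six-membered non-aromatic ring with 2 hetero atoms and the same counts of hydrogen-bond donors and acceptors, yet they stand apart, and the rings differ in a ring oxygen against a ring nitrogen carrying its methyl. Morpholin-4-yl in place of pyrrolidin-1-yl gives an at least 6.2-fold lower number from compound 1 to compound 3 (0.79 log units; beyond the scatter), a step that is only a floor, since compound 1 stands at a limit and has no number: the limit of > 25000 nM in this assay, at which 1 of the 3 values shown sits.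

Going by these compounds, whether the ring oxygen or the loss of the methyl-bearing nitrogen goes with the step stays open, and piperidin-1-yl, thiomorpholin-4-yl or piperazin-1-yl with its free amine hydrogen on the same thiocarbonyl carbon would separate the two. Also open, on these data alone, is whether a ring is needed at all, which an open-chain amine such as diethylamino would address.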